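A Methyl Added Near the Chain Start: What to Expect

The compounds below may be only part of what the source reports. "The series", "measured", "known", "first", "only" and "open" are said of these compounds alone.

Of the compounds shown here, three have so far been tested in an assay on isolated protein for binding affinity to Equilibrative nucleoside transporter 1 (Homo sapiens); on this read-out higher numbers stand for weaker inhibition and lower numbers for stronger inhibition. Compound 1 `CCCCn1cnc2c(SCc3ccccn3)nc(N)nc21` gives 52500 nM. Compound 2 `CCC(C)Sc1nc(N)nc2c1ncn2[C@@H]1O[C@H](CO)[C@@H](O)[C@H]1O` gives 63100 nM in this assay, and compound 3 `CC(C)Sc1nc(N)nc2c1ncn2[C@@H]1O[C@H](CO)[C@@H](O)[C@H]1O` gives 191000 nM. Compound 2 and compound 3 share a core and differ in one place: methyl in place of hydrogen on a saturated chain carbon, two bonds along the chain from a sulfur. That change gave a 3.0-fold lower number from compound 3 to compound 2 (0.48 log units; beyond the scatter). The cores of compound 1 and compound 3 are not the same, and the difference between the two cores is not broken down here. Compound 1 and compound 2 sit close to one another in this assay, while compound 3 lies further off.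

Compound 4 `CCCC(C)n1cnc2c(SCc3ccccn3)nc(N)nc21` has not yet been measured. It differs from compound 1 in one place: methyl in place of hydrogen on a saturated chain carbon bound to an aromatic nitrogen and a saturated chain carbon. Among the measured compounds shown here, this is the same kind of change as the one from compound 3 to compound 2, a methyl entering in place of a hydrogen, but the surroundings differ: in compound 4 the saturated chain carbon that receives the methyl is bound to an aromatic nitrogen and a saturated chain carbon, whereas in compound 2 it lies two bonds along the chain from a sulfur. For the measured compounds named here, because the earlier change gave a 3.0-fold lower number from compound 3 to compound 2 (0.48 log units; beyond the scatter), a lowering of the number is a reasonable expectation here too, though the different surroundings and the single example leave the size uncertain. Compound 4 is expected to show a 2.0-fold lower number from compound 1 to compound 4 (0.31 log units; beyond the scatter). Compound 4 is therefore estimated at 26000 nM in this assay, with a plausible range from 8000 nM to 80000 nM.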

Compound 4, half-maximal inhibitory concentration: 41700 nM
Estimate against measurement, compound 4: 1.6-fold (0.21 log units) below, within the range that was stated.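

In this assay, placing a methyl on the saturated chain carbon bound to an aromatic nitrogen, which turns butyl into 1-methylbutyl, gave a 1.3-fold lower number from compound 1 to compound 4 (0.10 log units; within the scatter), so compound 1 and compound 4 cannot be told apart on this read-out. Taken alone, the earlier step is beyond the scatter and the new one is within it, yet the gap between them is too small to count as a real difference: the same change on two cores in this assay, a 3.0-fold lower number (0.48 log units; beyond the scatter) from compound 3 to compound 2 and a 1.3-fold lower number (0.10 log units; within the scatter) from compound 1 to compound 4, 2.4-fold (0.38 log units) apart, within the scatter of two such steps. Among the compounds shown here, this shows that the two results are compatible with one shared effect of the methyl, but it does not show that the effect carries over from one core to the other, since there is only one pair per core and the methyl sits on a different chain in each pair.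

The compounds shown leave open whether a longer chain such as hexyl, or an amine or a carboxylic acid on the butyl chain of compound 1, would shift the number clearly beyond the scatter. They also leave open how the same methyl would behave on a third core, which would help to show whether the two steps reflect one common effect.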